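From 2-aminobenzyl to 3-aminobenzyl on a shared core

The compounds below may be only part of what the source reports. "The series", "measured", "known", "first", "only" and "open" are said of these compounds alone.

In an ADME assay on the whole organism (plasma) for pharmacokinetics, with Rattus norvegicus as the target, with a stated time of 6 h, at a dose of 10 mg/kg by the oral route (a higher number here means more compound in the circulation at the dose given, a lower number less compound in the circulation), compound 1 `CCOC(=O)c1ccc(CS(=O)(=O)N2CCN(c3cnn(-c4cccc(Cl)c4)c(=O)c3OC3CCCC3)CC2)cc1` has the entry "not determined" (no result reported) and so offers no number for comparison. For the measured compounds named here, compound 2 `Nc1ccccc1CS(=O)(=O)N1CCN(c2cnn(-c3cccc(Cl)c3)c(=O)c2OC2CCCC2)CC1` gives 290 ng.h/mL, the only number available, which leaves it with nothing to be ranked against. Compound 3 `Nc1cccc(CS(=O)(=O)N2CCN(c3cnn(-c4cccc(Cl)c4)c(=O)c3OC3CCCC3)CC2)c1` has not yet been measured. It has the same atoms as compound 2, joined differently, with 3-aminophenyl in place of 2-aminophenyl on a saturated chain carbon bound to a sulfonyl sulfur. Going by the values given here, no measured pair shows what such a change does, so the data give no direction for it, and no step beyond the usual scatter is expected in this assay. The expected step is a 1.2-fold lower number from compound 2 to compound 3 (0.06 log units; within the scatter). For compound 3 the estimated value is 250 ng.h/mL, with an expected range of 80 ng.h/mL to 800 ng.h/mL.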

Compound 3, area under the concentration-time curve: 50 ng.h/mL
The estimate for compound 3 lay 5.0-fold (0.70 log units) above the measured number; the whole stated range lies above it.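

With the two aminobenzyl groups compared directly in this assay, moving from 2-aminobenzyl to 3-aminobenzyl gives a 5.8-fold lower number from compound 2 to compound 3 (0.76 log units; beyond the scatter), the first step available at this position. It shows that changing 2-aminophenyl to 3-aminophenyl on the saturated chain carbon bound to the sulfonyl sulfur is enough to move the number beyond the usual scatter, even though the heavy atoms, the donor count and the acceptor count stay the same. Nothing in the available evidence bears on what lies behind this step.

The compounds shown leave open whether a carboxylic acid, a hydroxyl or a methoxy group in place of the amine would give a step of similar size when moved in the same way. They also leave open whether this step would recur on a different core.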